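Side-chain exchange on the shared core: notes on compound 4

A few compounds are considered here, and "the series" means these few. Any claim that something is new, unique, unknown or untested is made for them only; others in the source may bear on it.

Compound 1 `COCc1cccc2[nH]c(-c3n[nH]c4ncc(-c5ccncc5)cc34)nc12`: 3090 nM
Compound 2 `CN1CCN(c2ccc3[nH]c(-c4n[nH]c5ncc(-c6cncc7ccccc67)cc45)nc3c2)CC1`: 450 nM
Compound 3 `CC(C)OCc1cccc2[nH]c(-c3n[nH]c4ncc(-c5cncc6ccccc56)cc34)nc12`: 2400 nM

All numbers come from a functional assay on HeLa cells (Homo sapiens) for antiproliferative activity; on this read-out higher numbers stand for weaker inhibition and lower numbers for stronger inhibition. In this assay compound 3 gives 2400 nM, the second highest of the three values. Compound 1 stands nearest to it, within the scatter, so no order between compound 3 and compound 1 can be read from these two numbers. Compound 2 stands furthest from compound 3, at a lower number beyond the scatter; its substituent sits elsewhere on the shared core, so that gap says nothing about the change examined here.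

Compound 4 `CCN(CC)C(=O)c1cccc2[nH]c(-c3n[nH]c4ncc(-c5cncc6ccccc56)cc34)nc12` differs from compound 3 in one place: diethylcarbamoyl in place of isopropoxymethyl on an aromatic carbon. Among the compounds with values here, no pair of measured compounds shows this exchange, so its effect in this assay is unknown. The expected step is a 1.3-fold lower number from compound 3 to compound 4 (0.12 log units; within the scatter), with no direction asserted beyond the scatter and a wide range to reflect the missing precedent. Compound 4 is estimated at 1800 nM, with a range from 450 nM to 7000 nM.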

Compound 4, half-maximal inhibitory concentration: 170 nM
Beside the measured number, compound 4's estimate is 11-fold (1.02 log units) above it, outside the stated range (below it).
By their numbers in this assay, from the lowest: compound 4; then compound 2; then compounds 3 and 1 (each within the scatter of the next).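

In this assay, within the data shown here, the exchange of isopropoxymethyl for diethylcarbamoyl on this aromatic carbon gives a 14-fold lower number from compound 3 to compound 4 (1.15 log units; beyond the scatter), so the group held at this position bears heavily on the read-out, which the earlier compounds could not show. The computed counts of hydrogen-bond donors and acceptors are the same for both groups, so those counts do not separate them; the entering group differs in its nitrogen, its double bond outside aromatic rings and its larger number of heavy atoms. Nothing available indicates which of these differences, if any, accounts for the step.

Still open, on these data alone, is whether the step needs the whole diethylcarbamoyl group, or whether a carboxylic acid, an amine or a longer chain at this position would give a similar number. Also open, as far as these compounds go, is whether the same exchange carries over to the core of compound 1.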